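Thiourea Variants on Liver Cancer Cells: Predicting Compound 4

The source may report more compounds than this note shows. Statements on the series, on what has been measured and on what is new or still open speak of the compounds shown alone.

Compound 1, `CNC(=O)c1ccc(Oc2cccc(NC(=S)Nc3ccc(F)cc3)c2)nc1`, gives 42500 nM in a functional assay on HepG2 cells (Homo sapiens) for antiproliferative activity, read by MTT assay; a lower number here means a stronger inhibitor, a higher number a weaker inhibitor.
Compound 2, `CNC(=O)c1ccc(Oc2cccc(NC(=S)Nc3cc(C(F)(F)F)cc(C(F)(F)F)c3)c2)nc1`, gives 4550 nM in this assay.
Compound 3, `CNC(=O)c1ccc(Oc2cccc(NC(=S)Nc3ccc(OC)cc3)c2)nc1`, gives 85300 nM in this assay.

Compound 3 carries the highest of the three numbers. Its nearest neighbour is compound 1: the step of a 2.0-fold higher number from compound 1 to compound 3 (0.30 log units; within the scatter) lies within the scatter. Compound 2 lies furthest away, its value well beyond the scatter below that of compound 3.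

Compound 4, `CNC(=O)c1ccc(Oc2cccc(NC(=S)Nc3cccc(C(F)(F)F)c3)c2)nc1`, differs from compound 3 in one place: 3-(trifluoromethyl)phenyl in place of 4-methoxyphenyl on an amide-type nitrogen. Two comparisons bear on this step. The exchange of fluoro for methoxy, a 2.0-fold higher number from compound 1 to compound 3 (0.30 log units; within the scatter), moved little. Compound 2, bearing two trifluoromethyl groups, sits far below compound 3, so a single trifluoromethyl group is expected to bring a lower number, though probably a smaller shift than compound 2 shows: the expected step is a 5.7-fold lower number from compound 3 to compound 4 (0.75 log units; beyond the scatter). Compound 4 is therefore estimated at 15000 nM, within 5000 nM to 45000 nM.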

Compound 4, half-maximal inhibitory concentration: 23300 nM
Beside the measured number, compound 4's estimate is 1.6-fold (0.19 log units) below it; the measured number falls inside the stated range.
By their numbers in this assay, from the lowest: compound 2; then compounds 4, 1 and 3 (each within the scatter of the next, the first and the last beyond it).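

In this assay, 3-(trifluoromethyl)phenyl on the amide-type nitrogen gives a step beyond the scatter against 4-methoxyphenyl (a 3.7-fold lower number from compound 3 to compound 4 (0.56 log units; beyond the scatter)), while against 4-fluorophenyl the step stays within it (a 1.8-fold lower number from compound 1 to compound 4 (0.26 log units; within the scatter)). Hydrogen in place of one trifluoromethyl group also gives a step beyond the scatter (a 5.1-fold higher number from compound 2 to compound 4 (0.71 log units; beyond the scatter)), so a single trifluoromethyl group does not match the number of compound 2. No available evidence accounts for these steps. Going by these compounds, whether a nitrile or an amine in place of the trifluoromethyl group would give a lower number remains open.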